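Pyrimidinylethyl Thioether in Place of a Cumyl Group

The compounds below may be only part of what the source reports. "The series", "measured", "known", "first", "only" and "open" are said of these compounds alone.

Of the compounds shown here, three that share one core have been measured so far. Compound 1 `Cn1ncc2c(=O)n(-c3ccccc3)c(SC(C)(C)c3ccccc3)nc21` was tested in an assay on isolated protein for inhibition of aldehyde dehydrogenase 1A1 (Homo sapiens) (a lower number here means a stronger inhibitor, a higher number a weaker inhibitor), and gives 1900 nM. Compound 2 `Cn1ncc2c(=O)n(-c3ccccc3)c(OCc3cccc(F)c3)nc21` gives 775 nM in this assay, and compound 3 `Cn1ncc2c(=O)n(-c3ccccc3)c(CNc3cccc(F)c3)nc21` gives 570 nM. Among these three numbers compound 1 stands at the highest, with compound 2 nearest to it and compound 3 furthest away, and both gaps lie beyond the usual scatter of the measurement. Compound 4 `CC(Sc1nc2c(cnn2C)c(=O)n1-c1ccccc1)c1cncnc1` has not yet been measured in this assay. It differs from compound 1 in a single place: 1-(pyrimidin-5-yl)ethyl in place of 1-methyl-1-phenylethyl on a sulfur. Among the compounds with values here, no pair of measured compounds differing in only one place is available, so the size of this step cannot be read from a comparable case. A modest move toward a lower number is expected, one that may not exceed the scatter, and the expected step of a 1.6-fold lower number from compound 1 to compound 4 (0.20 log units; within the scatter) states that view. Compound 4 is accordingly estimated at 1200 nM, with a range from 400 nM to 4000 nM.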

Compound 4, half-maximal inhibitory concentration: 94 nM
Beside the measured number, compound 4's estimate is 13-fold (1.11 log units) above it; the measured number lies below the stated range.
By their numbers in this assay, from the lowest: compound 4; then compounds 3 and 2 (each within the scatter of the next); then compound 1.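

On the sulfur of the shared core, 1-(pyrimidin-5-yl)ethyl in place of 1-methyl-1-phenylethyl gives a 20-fold lower number from compound 1 to compound 4 (1.31 log units; beyond the scatter) in this assay. Within the data shown here, this is the only step here that can be read at a single place, and it shows that the number in this assay depends strongly on the group at this position. The change replaces a six-membered aromatic ring of carbon only with one holding 2 hetero atoms and also alters the carbon that joins the ring to the sulfur, and no measurement shown explains the size of the step.

The compounds shown leave open which of these two differences carries the step. As far as these compounds go, a plain 1-phenylethyl group or a 1-(pyridin-3-yl)ethyl group on the same sulfur would separate them, and a longer chain between the sulfur and the pyrimidine remains untested here as well.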